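The source may hold more compounds than are shown below. What is called first, only, known or untested is meant among the compounds shown, and "the series" means these compounds.

In a functional assay on SW-620 cells (Homo sapiens) for antiproliferative activity, read by CCK-8 assay and cell counting, with a stated time of 72 h (a higher number here means a weaker inhibitor, a lower number a stronger inhibitor), compound 1 (`O=C(Nc1ccccc1OC(=O)c1cccc(CO[N+](=O)[O-])c1)c1cccc(CO[N+](=O)[O-])c1`) gives 25800 nM and compound 2 (`O=C(Nc1cccc(OC(=O)c2ccc(CO[N+](=O)[O-])cc2)c1)c1ccc(CO[N+](=O)[O-])cc1`) gives 7600 nM as its reading. Compound 3 (`O=C(Nc1ccccc1)c1ccc(CCl)cc1`) gives 800 nM as the lowest number of the three, which makes it the strongest inhibitor so far, and its gaps to compound 1 and to compound 2 both lie beyond the usual scatter of repeat measurements.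

Compound 4 (`CCc1ccc(C(=O)Nc2ccccc2)cc1`) has not yet been measured. It differs from compound 3 in one place: methyl in place of chloro on a saturated chain carbon bound to an aromatic carbon with methyl in place of chloro on a saturated chain carbon bound to an aromatic carbon, so chloromethyl becomes ethyl. Among the measured compounds shown here, no measured pair shows this change directly, so any forecast is uncertain. Since compound 3 at 800 nM already holds the lowest number, a change to it seems more likely to raise the number than to lower it. The expected step is a 5.0-fold higher number from compound 3 to compound 4 (0.70 log units; beyond the scatter) in the direction of weaker inhibition, which would lie beyond the scatter. Compound 4 is estimated at 4000 nM with an expected range from 1200 nM to 15000 nM in this assay.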

Compound 4, half-maximal inhibitory concentration: > 100000 nM
Compound 4: only a limit was reported; the forecaster's own chance of this, stated with the estimate: 10%; middle value at least 25-fold (1.39 log units) from the limit.
By their numbers in this assay, from the lowest: compound 3; then compound 2; then compound 1. At a limit, above all of these: compound 4.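

Changing a single atom on a saturated chain carbon bound to an aromatic carbon, so that chloromethyl becomes ethyl, gives an at least 120-fold higher number from compound 3 to compound 4 (2.09 log units; beyond the scatter) in this assay. This pair shows that the activity of compound 3 depends heavily on the chloro at this place, since methyl, with the same count of heavy atoms, leaves the rest of the structure untouched and yet the reading collapses. Compound 4 has only a limit, not a number, so the true size of the step stays unknown and the printed step is a floor: the limit of > 100000 nM in this assay, at which 1 of the 4 values shown sits.

Going by these compounds, it remains open how a bromo, a hydroxyl or an amine on this same carbon would read, and whether any of them would come close to compound 3. One pair gives the size of the change but says nothing of how the chloro acts.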